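One Ring Swap on a Shared Core

The compounds below may be only part of what the source reports. "The series", "measured", "known", "first", "only" and "open" are said of these compounds alone.

Compound 1, `C/C(=N/NC(=O)Nc1nc(-c2ccc(F)cc2)cc(-c2ccc([N+](=O)[O-])cc2)n1)c1ccc(C)cc1`: 300 mg/kg
Compound 2, `C/C(=N/NC(=O)Nc1nc(-c2ccc(C)cc2)cc(-c2ccc(F)cc2)n1)c1ccc([N+](=O)[O-])cc1`: 300 mg/kg
Compound 3, `COc1ccc(-c2cc(-c3ccc(Cl)cc3)nc(NC(=O)N/N=C\c3ccc([N+](=O)[O-])cc3)n2)cc1OC`: 100 mg/kg

All three were tested in a functional assay on the whole organism (strain Albino) with Mus musculus as the target, with a stated time of 4 h; a higher number here means that more compound is needed for the effect, a lower number that less compound is needed. Compound 3 gives the lowest number of the three, and the gap to compound 1 and to compound 2 lies beyond the usual scatter, so compound 3 needs the least compound for the effect among those measured.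

Compound 4, `COc1ccc(-c2cc(-c3ccc(Cl)cc3)nc(NC(=O)N/N=C\c3cccc(Cl)c3)n2)cc1OC`, has not yet been measured in this assay. It differs from compound 3 in one place: 3-chlorophenyl in place of 4-nitrophenyl on a carbon with a double bond to nitrogen. No comparable change is available among the measured compounds, so nothing here shows which way this swap would move the number.

Compound 4 is therefore expected to stay close to compound 3, with an estimated step of no change at the digits printed from compound 3 to compound 4 (within the scatter) that does not go beyond the scatter. The estimate for compound 4 is 100 mg/kg, within a range of 50 mg/kg to 300 mg/kg.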

Compound 4, dose for half-maximal effect: 300 mg/kg
For compound 4 the middle estimate is 3.0-fold (0.48 log units) below the measured one; low and high end bracket the measured number.
By their numbers in this assay, from the lowest: compound 3; then compounds 1, 2 and 4 (each within the scatter of the next).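

In this assay, 3-chlorophenyl in place of 4-nitrophenyl on a carbon with a double bond to nitrogen gives a 3.0-fold higher number from compound 3 to compound 4 (0.48 log units; beyond the scatter) and so more compound is needed for the effect. Among the compounds shown here, this is the first single-place comparison in the set, and it shows that this position is not indifferent to the ring it carries, though the step is modest. Nothing available gives a reason for this shift.

The two rings differ in both their group and its ring position, so this step cannot separate those two changes. As far as these compounds go, how a plain phenyl, or a phenyl carrying an amine or a carboxylic acid, would behave here stays open.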